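The source may hold more compounds than are shown below. What is called first, only, known or untested is meant among the compounds shown, and "the series" means these compounds.

In an ADME assay on Vero cells (Chlorocebus sabaeus) for cytotoxicity (a lower number here means that less compound is tolerated, a higher number that more compound is tolerated), compound 1 `COc1ccc(-c2nc3cc(C(F)(F)F)ccc3[nH]2)c(OC)c1OC` gives 70000 nM. Compound 2 `COc1ccc(-c2nc3cc(C(C)=O)ccc3[nH]2)c(OC)c1` gives > 100000 nM, which is a limit of the assay and not a number, so its true position is not known. Compound 3 `COc1ccc(-c2nc3cc(C(C)=O)ccc3[nH]2)c(OC)c1OC` differs from compound 2 by methoxy in place of hydrogen on an aromatic carbon, with methoxy in place of hydrogen on an aromatic carbon. For the measured compounds named here, no measured pair shows this change alone. The estimated at least 1.1-fold lower number from compound 2 to compound 3 (0.04 log units; that floor lies within the scatter) is small and points downward. This expectation rests on compound 1, which carries the same methoxy and gives 70000 nM. For compound 3 the expected value is 90000 nM, with an estimated range of 40000 nM to 200000 nM.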

Compound 3, half-maximal cytotoxic concentration: > 100000 nM
Compound 3 was reported as a limit; the forecaster's own chance of this, stated with the estimate: 50%; at least 1.1-fold (0.04 log units) between middle value and limit.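

In this assay compound 3 gives > 100000 nM, which is a limit of the assay and not a number. The added methoxy thus brings no readable fall at this place, ortho to two methoxy groups, but its step cannot be read, because compound 2 and compound 3 both stop at the same limit: the limit of > 100000 nM in this assay, at which 2 of the 3 values shown sit. Acetyl in place of trifluoromethyl gives an at least 1.4-fold higher number from compound 1 to compound 3 (0.15 log units; that floor lies within the scatter), so this change is known only as a floor. Still open, from the compounds shown here alone, are the true values of compound 2 and compound 3, and whether an amine or an ethoxy group at this place would give a readable number.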